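This account rests on a few compounds, and the source may have more. Where it says the series, first, only, none or still open, it means among the compounds named here.

Compound 2 `CN(C)CCCOc1ccc(CN2CC[C@H](NC(=O)c3ccncc3)C2)cc1` carries a pyridin-4-yl group on the carbonyl carbon of a shared core. In an assay on HEK293 cells for binding affinity to Urotensin-2 receptor (Homo sapiens), read by radioligand binding (a higher number here means a weaker inhibitor, a lower number a stronger inhibitor), compound 2 gives only a limit, < 10000 nM, so no number is known for it. Compound 1 `Cc1cc(C(=O)N[C@H]2CCN(Cc3ccc(OCCCN(C)C)cc3)C2)ccc1Br` carries a 4-bromo-3-methylphenyl group at the same place, and in this assay compound 1 gives 631 nM. The step from compound 1 to compound 2 is a step that the limit leaves unreadable from compound 1 to compound 2, and the limit of < 10000 nM in this assay, at which 1 of the 2 values shown sits, is the reason its size cannot be read. Compound 3 `CN(C)CCCOc1ccc(CN2CC[C@H](NC(=O)c3ccc4ccccc4c3)C2)cc1` differs from compound 2 by naphthalen-2-yl in place of pyridin-4-yl on a carbonyl carbon. Within the data shown here, only that unreadable step bears on this change, so its size offers no guide, and the value of compound 1 stands as the nearest measured point for a carbon-only aromatic group at this place. Compound 3 is therefore expected to land near that point, an estimated step that the limit leaves unreadable from compound 2 to compound 3 in this assay. The estimate for compound 3 is 500 nM, within 100 nM to 3000 nM.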

Compound 3, inhibition constant: < 10000 nM
Compound 3 gave a limit, no number; the forecaster's own chance of this, stated with the estimate: 10%; the middle value lies beyond the limit too.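

Among these compounds, compound 3, like compound 2, gives only a limit in this assay and no number, so no step among compound 1, compound 2 and compound 3 can be read, because of this: the limit of < 10000 nM in this assay, at which 2 of the 3 values shown sit.
As far as these compounds go, how strong an inhibitor compound 2 or compound 3 really is stays open, and so does how pyridin-4-yl and naphthalen-2-yl compare with 4-bromo-3-methylphenyl on the carbonyl carbon.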